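A few compounds are considered here, and "the series" means these few. Any claim that something is new, unique, unknown or untested is made for them only; others in the source may bear on it.

Two related sulfonamides have so far been tested in an assay on cells for inhibition of HSP60/HSP10 (Homo sapiens), with a stated time of 60 min; a lower number here means a stronger inhibitor, a higher number a weaker inhibitor. Compound 1 `Cc1ccc(S(=O)(=O)Nc2ccc(-c3nc4ccccc4o3)cc2)cc1` gives > 100000 nM, which is a limit of the measurement rather than a number. Compound 2 `C=Cc1ccc(S(=O)(=O)Nc2ccc3oc(-c4ccccc4)nc3c2)cc1` gives > 100000 nM in this assay, again a limit rather than a number. Compound 2 thus stands where every value recorded so far stands, at the edge of what the measurement can report: the limit of > 100000 nM in this assay, at which 2 of the 2 values shown sit. Compound 3 `COc1ccccc1S(=O)(=O)Nc1ccc2oc(-c3ccccc3)nc2c1` has not yet been measured. It differs from compound 2 in one place: 2-methoxyphenyl in place of 4-vinylphenyl on a sulfonyl sulfur. For the measured compounds named here, no step between two measured compounds is available to gauge how such a change moves the read-out, and both measured compounds sit at the limit. The expected step is a number no higher from compound 2 to compound 3 (the limit leaves the size open), no larger than the usual scatter, most likely ending again at the limit. For compound 3 in this assay the estimated half-maximal inhibitory concentration is 100000 nM, within 40000 nM to 300000 nM.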

Compound 3, half-maximal inhibitory concentration: > 100000 nM
Compound 3 gave a limit, no number; the forecaster's own chance of this, stated with the estimate: 85%; the middle value lies on the limit itself.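

Compound 2 and compound 3 both end at a limit rather than a number, so swapping 4-vinylphenyl for 2-methoxyphenyl gives no readable step in this assay. The compounds shown leave open which change, if any, would yield an actual number, because all of them rest at the same edge: the limit of > 100000 nM in this assay, at which 3 of the 3 values shown sit.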